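The source may report more compounds than this note shows. Statements on the series, on what has been measured and on what is new or still open speak of the compounds shown alone.

Measured compounds:
compound 1 `CCOc1ccc(/C=C/c2ccc3cccc(O)c3n2)cc1` gives 4.55 in a physicochemical assay for lipophilicity, read by HPLC; a lower number here means a more polar compound, a higher number a more lipophilic compound
compound 2 `Oc1ccccc1/C=C/c1ccc2cccc(O)c2n1` gives 3.95 in this assay
compound 3 `Oc1ccc(/C=C/c2ccc3cccc(O)c3n2)c(O)c1` gives 3.56 in this assay

Compound 1 stands highest of the three in this assay; compound 2 lies nearest and compound 3 furthest. The difference between the core of compound 1 and the core of compound 3 is not broken down here. For the measured compounds named here, the one counted step is hydrogen in place of hydroxy on an aromatic carbon, which gave a number 0.39 log units higher from compound 3 to compound 2 (beyond the scatter). Compound 4 `CCOc1ccc(/C=C/c2ccc3ccccc3n2)cc1` is not yet measured; it differs from compound 1 by hydrogen in place of hydroxy on an aromatic carbon. This is the same kind of change as from compound 3 to compound 2, but the place is not the same: in compound 4 the hydroxy leaves an aromatic carbon that is part of a fused or bridged system of two rings, ortho to a fused ring and meta to a fused ring, whereas in compound 2 it left a carbon meta to a hydroxy group and para to a large group. Resting on the step from compound 3 to compound 2 a number 0.39 log units higher from compound 3 to compound 2 (beyond the scatter), a step of a number 0.40 log units higher from compound 1 to compound 4 (beyond the scatter) is expected from compound 1 to compound 4 in this assay. Compound 4 is therefore estimated at 4.95, expected to fall between 4.6 and 5.3.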

Compound 4, partition coefficient: 4.61
Compound 4: the middle estimate sits 0.34 log units above what was measured; the range from low to high includes it.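

In this assay hydrogen in place of hydroxy on an aromatic carbon does not carry over as one fixed step: the change gave a number 0.39 log units higher from compound 3 to compound 2 (beyond the scatter) but gave a number 0.06 log units higher from compound 1 to compound 4 (within the scatter) on a carbon that is part of a fused or bridged system of two rings. Core and place both differ between these two steps, and two cases cannot show which of the two matters. Nothing at hand accounts for the contrast between the steps.

Going by these compounds, whether an amine or a carboxylic acid in place of that hydroxy would give a step of either size stays open. So does the size of the same change at other carbons of the shared core.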